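The source may report more compounds than this note shows. Statements on the series, on what has been measured and on what is new or still open speak of the compounds shown alone.

Within the data shown here, compound 2, `COc1cc(-n2cnc3ccc(-c4cccc(O)c4)cc32)cc(OC)c1OC`, is one of two compounds measured in a functional assay on A549 cells (Homo sapiens) for antiproliferative activity, read by MTT assay, with a stated time of 72 h (a higher number here means a weaker inhibitor, a lower number a stronger inhibitor), where compound 2 gives 250 nM. Among the measured compounds shown here, it stands alongside the only other measured compound, compound 1, `COc1ccc(-c2ccc3ncn(-c4cc(OC)c(OC)c(OC)c4)c3c2)cc1O`, which in this assay gives 200 nM, a number within the scatter of that of compound 2. The change of hydrogen in place of methoxy on an aromatic carbon between these two produced a 1.3-fold higher number from compound 1 to compound 2 (0.10 log units; within the scatter). Compound 3, `COc1ccc(-c2ccc3ncn(-c4cc(OC)c(OC)c(OC)c4)c3c2)cc1`, has not yet been measured; it differs from compound 2 in that (4-methoxyphenyl in place of 3-hydroxyphenyl on an aromatic carbon). For the measured compounds named here, the single step that bears on this change, the one between compound 1 and compound 2, alters the same pendant ring and stayed within the scatter, so no step beyond the scatter is expected in this assay. Compound 3 is therefore estimated to give 280 nM, with a range from 100 nM to 800 nM. The expected step is a 1.1-fold higher number from compound 2 to compound 3 (0.05 log units; within the scatter).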

Compound 3, half-maximal inhibitory concentration: > 10000 nM
Compound 3 gave a limit, no number (the forecaster's own chance of this, stated with the estimate: 3%); middle value at least 35-fold (1.55 log units) from the limit.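

In this assay compound 3 gave a limit and not a number: the limit of > 10000 nM in this assay, at which 1 of the 3 values shown sits. On this pendant ring, the hydroxy group proved to be the change that counts: hydrogen in place of hydroxy gave an at least 50-fold higher number from compound 1 to compound 3 (1.69 log units; beyond the scatter), and 4-methoxyphenyl in place of 3-hydroxyphenyl gave an at least 40-fold higher number from compound 2 to compound 3 (1.60 log units; beyond the scatter), while hydrogen in place of methoxy had given only a 1.3-fold higher number from compound 1 to compound 2 (0.10 log units; within the scatter). Among these three compounds, the methoxy group could therefore be lost with no step beyond the scatter, whereas the only compound without the hydroxy group is the one at the limit.

As far as these compounds go, how far compound 3 lies past that limit stays open, since the limit gives no number. Also open, from the compounds shown here alone, is whether an amine or a hydroxymethyl group at this place on the ring would serve as the hydroxy group does.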